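Taking one chloro off compound 3

The compounds below may be only part of what the source reports. "The series", "measured", "known", "first", "only" and "open" are said of these compounds alone.

Measured in a functional assay on U-251 cells (Homo sapiens) for inhibition, read by MTT assay, with a stated time of 2 days; a higher number here means a weaker inhibitor of growth, a lower number a stronger inhibitor of growth:
Compound 1 `Nc1ccccc1NC(=O)CCCNCC(=O)Nc1ccc(Cl)cc1`: 11400 nM
Compound 2 `Nc1ccccc1NC(=O)CCCNCC(=O)Nc1ccc(Br)cc1`: 10400 nM
Compound 3 `Nc1ccccc1NC(=O)CCCNCC(=O)Nc1cc(Cl)ccc1Cl`: 44000 nM

Compound 3 carries the highest number of the three, and so shows the weakest growth inhibition in this set. Compound 4 `Nc1ccccc1NC(=O)CCCNCC(=O)Nc1ccccc1Cl` has not yet been measured. It differs from compound 3 by hydrogen in place of chloro on an aromatic carbon, turning 2,5-dichlorophenyl into 2-chlorophenyl: hydrogen in place of chloro on an aromatic carbon.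

Within the data shown here, no measured step isolates this exact change. The nearest evidence is a 3.9-fold higher number from compound 1 to compound 3 (0.59 log units; beyond the scatter) and a 4.2-fold higher number from compound 2 to compound 3 (0.63 log units; beyond the scatter), both of which alter the substitution on the same aryl group. The step of a 1.1-fold lower number from compound 1 to compound 2 (0.04 log units; within the scatter) concerns a different change and adds little. A modest step toward a lower number is therefore expected, probably no larger than those two. The expected step is a 2.0-fold lower number from compound 3 to compound 4 (0.30 log units; within the scatter). For compound 4, the estimate is 22000 nM, with an expected range from 9000 nM to 50000 nM.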

Compound 4, concentration for 50% growth inhibition: 28600 nM
Compound 4: the middle estimate sits 1.3-fold (0.11 log units) below what was measured; the measured number falls inside the stated range.
By their numbers in this assay, from the lowest: compounds 2 and 1 (each within the scatter of the next); then compounds 4 and 3 (each within the scatter of the next).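

In this assay, hydrogen in place of chloro, at the place para to a chloro group, gives a 1.5-fold lower number from compound 3 to compound 4 (0.19 log units; within the scatter), so the chloro that compound 3 loses here has no effect that can be told from the scatter. The 2-chlorophenyl group alone still leaves compound 4 apart from the 4-halophenyl compounds, with a 2.5-fold higher number from compound 1 to compound 4 (0.40 log units; beyond the scatter) and a 2.8-fold higher number from compound 2 to compound 4 (0.44 log units; beyond the scatter), so among these compounds the higher numbers do not depend on having both chloro groups. Nothing at hand explains this result.

The compounds shown leave open what hydrogen, a methoxy group or an amine would do in place of the remaining chloro of compound 4. They also leave open whether a longer chain in the shared core would change the gap between the 2-chlorophenyl and 4-chlorophenyl compounds.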